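Swapping a naphthyl for a methoxyphenyl on the amine

The source may report more compounds than this note shows. Statements on the series, on what has been measured and on what is new or still open speak of the compounds shown alone.

Of the compounds shown here, three sharing one core have been tested in a functional assay on MCF7 cells (Homo sapiens) for cytotoxicity, read by sulforhodamine B assay; on this read-out lower numbers stand for stronger inhibition and higher numbers for weaker inhibition. Compound 1 `C=C1[C@@H](OC(C)=O)C[C@@H]2[C@](C)(CO[Si](C)(C)C(C)(C)C)[C@H](OC(C)=O)CC[C@@]2(C)[C@@H]1C[C@@H](Nc1ccc(OC)cc1)C1=CCOC1=O` gives 4280 nM. Compound 2 `C=C1[C@@H](OC(C)=O)C[C@@H]2[C@](C)(COC=O)[C@H](OC(C)=O)CC[C@@]2(C)[C@@H]1C[C@@H](Nc1ccc(O)cc1)C1=CCOC1=O` gives 18100 nM, and compound 3 `C=C1[C@@H](OC(C)=O)C[C@@H]2[C@](C)(COC=O)[C@H](OC(C)=O)CC[C@@]2(C)[C@@H]1C[C@@H](Nc1cccc2ccccc12)C1=CCOC1=O` gives 9750 nM. On these three numbers compound 3 stands second highest: its nearest neighbour is compound 2, which lies within the scatter, while compound 1 lies beyond it, with the lower number.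

The next compound, compound 4 `C=C1[C@@H](OC(C)=O)C[C@@H]2[C@](C)(COC=O)[C@H](OC(C)=O)CC[C@@]2(C)[C@@H]1C[C@@H](Nc1ccc(OC)cc1)C1=CCOC1=O`, differs from compound 3 in one place: 4-methoxyphenyl in place of naphthalen-1-yl on an amine nitrogen. Among the measured compounds shown here, only one measured step touches the same position. The change a 1.9-fold lower number from compound 2 to compound 3 (0.27 log units; within the scatter) stayed within the scatter, which suggests that exchanging one aromatic group for another on this amine nitrogen need not move the number much. Compound 4 carries the same 4-methoxyphenyl group as compound 1, which differs elsewhere in the core. The value of compound 1, 4280 nM, sits below that of compound 3.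

Compound 4 is therefore expected to land near or somewhat below compound 3 in this assay, with an estimated step of a 1.5-fold lower number from compound 3 to compound 4 (0.18 log units; within the scatter). The estimate for compound 4 is 6500 nM, with a range from 2500 nM to 16000 nM.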

Compound 4, half-maximal inhibitory concentration: 24200 nM
Beside the measured number, compound 4's estimate is 3.7-fold (0.57 log units) below it; measured number above the stated range.
By their numbers in this assay, from the lowest: compound 1; then compounds 3, 2 and 4 (each within the scatter of the next, the first and the last beyond it).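

In this assay, this amine nitrogen now shows a step beyond the scatter: a 2.5-fold higher number from compound 3 to compound 4 (0.39 log units; beyond the scatter), so the two aromatic groups are not interchangeable here, though the change is modest. The methyl on the aromatic oxygen, by contrast, has no readable effect, with a 1.3-fold higher number from compound 2 to compound 4 (0.13 log units; within the scatter), and a second site also matters: with 4-methoxyphenyl held constant, putting the group of 2 heavy atoms in place of the silicon-bearing group of 7 heavy atoms, on an oxygen on a saturated carbon, gives a 5.7-fold higher number from compound 1 to compound 4 (0.75 log units; beyond the scatter). No measurement shown here explains either shift.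

Among the compounds shown here, only three aromatic groups have been compared on this nitrogen, so it remains open where a plain phenyl or a 4-chlorophenyl would fall, and whether the second ring of naphthalen-1-yl or the methoxy group accounts for the difference. As far as these compounds go, it is also open whether the silicon-bearing group would give a similar step with naphthalen-1-yl on the amine nitrogen, and how a free hydroxyl on that same saturated-carbon oxygen position would compare.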